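Cytotoxicity notes: pyridyl for phenyl on the benzyl arm

This account rests on a few compounds, and the source may have more. Where it says the series, first, only, none or still open, it means among the compounds named here.

Among the compounds with values here, compound 3 `O=C(Nc1ccc(NCc2ccc(Cl)cc2)cc1Cl)c1cc(Cl)ccc1O` stands highest among the three measured members in an ADME assay on A549 cells (Homo sapiens) for cytotoxicity, read by resazurin assay, with a stated time of 48 h (a lower number here means that less compound is tolerated, a higher number that more compound is tolerated), giving 59700 nM. Compound 1 `CCNc1ccc(NC(=O)c2cc(Cl)ccc2O)c(Cl)c1` gives 30200 nM and compound 2 `O=C(Nc1ccc(N(CC2CC2)CC2CC2)cc1Cl)c1cc(Cl)ccc1O` gives 12800 nM. Of the measured steps, a 2.0-fold higher number from compound 1 to compound 3 (0.30 log units; within the scatter), whereas a 4.7-fold higher number from compound 2 to compound 3 (0.67 log units; beyond the scatter) and a 2.4-fold lower number from compound 1 to compound 2 (0.37 log units; beyond the scatter).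

Compound 4 `O=C(Nc1ccc(NCc2cccnc2Cl)cc1Cl)c1cc(Cl)ccc1O` differs from compound 3 in one place: 2-chloropyridin-3-yl in place of 4-chlorophenyl on a saturated chain carbon bound to a nitrogen on an aromatic ring. Within the data shown here, no measured step reproduces an exchange of this kind. Among the measured compounds shown here, the nearest is a 2.0-fold higher number from compound 1 to compound 3 (0.30 log units; within the scatter), where methyl became 4-chlorophenyl on the saturated chain carbon bound to a nitrogen on an aromatic ring and the number stayed within the scatter; the only steps beyond the scatter arose when bis(cyclopropylmethyl)amino was present, which neither compound 3 nor compound 4 carries. For the measured compounds named here, replacing 4-chlorophenyl by 2-chloropyridin-3-yl is a smaller alteration than the one in that step, so no step beyond the scatter is expected in this assay. The expected step is a 1.2-fold lower number from compound 3 to compound 4 (0.08 log units; within the scatter). For compound 4 the estimate in this assay is 50000 nM, with a range from 20000 nM to 120000 nM.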

Compound 4, half-maximal cytotoxic concentration: 101000 nM
For compound 4 the middle estimate is 2.0-fold (0.31 log units) below the measured one; measured number inside the range.
By their numbers in this assay, from the lowest: compound 2; then compounds 1, 3 and 4 (each within the scatter of the next, the first and the last beyond it).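

At the saturated chain carbon bound to a nitrogen on an aromatic ring, 2-chloropyridin-3-yl in place of 4-chlorophenyl stays within the scatter in this assay (a 1.7-fold higher number from compound 3 to compound 4 (0.23 log units; within the scatter)), so a ring nitrogen, counted as a hydrogen-bond acceptor in the entering group, is accommodated at this position. Against the ethylamino compound, the aromatic arm now gives a step beyond the scatter (a 3.3-fold higher number from compound 1 to compound 4 (0.52 log units; beyond the scatter)), which the 4-chlorophenyl step did not, and the gap to the bis(cyclopropylmethyl)amino compound is also beyond it (a 7.9-fold higher number from compound 2 to compound 4 (0.90 log units; beyond the scatter)). Nothing available explains these differences.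

The exchange alters the ring nitrogen and the chlorine placement together, and the compounds shown do not separate the two. On these data alone, how pyridin-3-yl without chlorine or 2-chlorophenyl on the same carbon would read in this assay stays open.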